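The compounds below may be only part of what the source reports. "The series", "measured", "known", "first", "only" and "open" are said of these compounds alone.

Compound 1 `CCCC(CCC(=O)O)Cc1cccc(OCc2ccc3ccccc3n2)c1` was tested in an assay on membranes from lung (Cavia porcellus) for binding affinity to cysteinyl leukotriene receptor (Homo sapiens) (a higher number here means a weaker inhibitor, a lower number a stronger inhibitor), and gave 50 nM. Two other compounds on the same core were measured alongside it: compound 2 `c1cc(OCCCc2nnn[nH]2)cc(OCc2ccc3ccccc3n2)c1` gave 42 nM, and compound 3 `O=C(O)C1CCC(c2ccc(OCc3ccc4ccccc4n3)cc2)C1` gave 43 nM. Compound 1 has the highest of the three numbers, but its gaps to compound 3 and to compound 2 both lie within the usual scatter, so the three compounds cannot be told apart on these data.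

Compound 4 `CC(CCc1cccc(OCc2ccc3ccccc3n2)c1)Cc1nnn[nH]1` has not yet been measured. It differs from compound 1 in one place: 2-((1H-tetrazol-5-yl)methyl)propyl in place of 1-(2-carboxyethyl)butyl on a saturated chain carbon bound to an aromatic carbon. No pair of measured compounds shows exactly this exchange, so its effect must be judged from what is shown. Compound 2 also carries a tetrazole and gives 42 nM, a number close to that of compound 1. On that basis a step from compound 1 to compound 4 of a 1.3-fold lower number from compound 1 to compound 4 (0.10 log units; within the scatter) is expected, that is, no change beyond the scatter in either direction. The estimate for compound 4 in this assay is therefore 40 nM, within a range from 15 nM to 110 nM.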

Compound 4, inhibition constant: 17 nM
Compound 4: the middle estimate sits 2.4-fold (0.37 log units) above what was measured; the measured number falls inside the stated range.
By their numbers in this assay, from the lowest: compound 4; then compounds 2, 3 and 1 (each within the scatter of the next).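

In this assay, placing 2-((1H-tetrazol-5-yl)methyl)propyl in place of 1-(2-carboxyethyl)butyl on a saturated chain carbon bound to an aromatic carbon gives a 2.9-fold lower number from compound 1 to compound 4 (0.47 log units; beyond the scatter), the only step shown and one that lies beyond the scatter. Within the data shown here, this shows that the number responds to a change at this place, which the earlier compounds could not show, since they lie within the scatter of one another and no single-place step joined them. Nothing measured here explains the step.

The exchange alters both the terminal group and the chain that carries it, so the compounds shown leave open which of the two accounts for the step. On these data alone, a carboxylic acid on the chain of compound 4 or a tetrazole on the chain of compound 1 would separate them, and the effect of an amine or a longer chain at this place also remains open.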